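The compounds below may be only part of what the source reports. "The series", "measured", "known", "first", "only" and "open" are said of these compounds alone.

Measured compounds:
- Compound 1 `O=S(=O)(NCc1csc2ccccc12)c1ccc(F)cc1`: 98600 nM
- Compound 2 `O=S(=O)(NCc1csc2ccccc12)c1ccc(Br)cc1`: 87100 nM
- Compound 3 `Cc1ccc(S(=O)(=O)NCc2csc3ccccc23)cc1`: > 210000 nM

In an ADME assay on MDCK cells (Canis lupus familiaris) for cytotoxicity, read by MTT assay, with a stated time of 24 h (on this read-out higher numbers stand for lower toxicity in this test and lower numbers for higher toxicity in this test), compound 3 has only a limit, > 210000 nM, and not an exact number.

Compound 4 `CC(=O)c1ccc(S(=O)(=O)NCc2csc3ccccc23)cc1` has acetyl in place of methyl on an aromatic carbon.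

Three measured changes on an aromatic carbon bear on this. Two reach the methyl: an at least 2.1-fold higher number from compound 1 to compound 3 (0.32 log units; beyond the scatter) and an at least 2.4-fold higher number from compound 2 to compound 3 (0.38 log units; beyond the scatter), both beyond the scatter. The third, a 1.1-fold lower number from compound 1 to compound 2 (0.05 log units; within the scatter), stays within it. Neither compound 1 nor compound 2 carries acetyl, so these steps are only a rough guide. They suggest that replacing the methyl may give a lower number, by a modest step.

In this assay, the expected change is an at least 1.7-fold lower number from compound 3 to compound 4 (0.24 log units; that floor lies within the scatter).

The estimate for compound 4 is 120000 nM, with an expected range of 55000 nM to 230000 nM.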

Compound 4, half-maximal cytotoxic concentration: > 193000 nM
Compound 4 was reported as a limit; the forecaster's own chance of this, stated with the estimate: 25%; middle value at least 1.6-fold (0.20 log units) away from the limit.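

In this assay, acetyl on this aromatic carbon, para to a large group, gives an at least 2.2-fold higher number from compound 2 to compound 4 (0.34 log units; beyond the scatter) and an at least 1.9-fold higher number from compound 1 to compound 4 (0.29 log units; that floor lies within the scatter). Methyl is therefore no longer the only group here with a number clearly higher than that of compound 2, although the floor against compound 1 does not clear the scatter. Compound 3 and compound 4 are both reported only as limits, so the step between them cannot be read.

On these data alone, their exact numbers stay open, as does what an amine or a carboxylic acid at this position would give.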